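The source may hold more compounds than are shown below. What is called first, only, known or untested is meant among the compounds shown, and "the series" means these compounds.

Measured in a functional assay on the whole organism for agonist activity, with Mus musculus as the target; on this read-out lower numbers stand for an effect already at smaller amounts and higher numbers for an effect only at larger amounts of compound:

- Compound 1 `COC(=O)N(C)CC#CCN(C)C` gives 9.7 mg/kg
- Compound 2 `COC(=O)N(C)C(C)C#CCN1CCCC1` gives 20.9 mg/kg
- Compound 3 `COC(=O)N(C)C(C)C#CCn1ccnc1` gives 8 mg/kg

In this assay compound 3 stands level with compound 1 within the scatter and under compound 2 by more than the scatter. Going by the values given here, the single measured step that reaches it is a 2.6-fold lower number from compound 2 to compound 3 (0.42 log units; beyond the scatter) with 1H-imidazol-1-yl in place of pyrrolidin-1-yl.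

Compound 4 `COC(=O)N(C)C(C)C#CCN(C)C` changes that same place again, and the change is dimethylamino in place of 1H-imidazol-1-yl on a saturated chain carbon bound to a triple-bonded carbon in the structure. Among the compounds with values here, no measured step makes this exact exchange. The closest guide is a 2.6-fold lower number from compound 2 to compound 3 (0.42 log units; beyond the scatter) in which 1H-imidazol-1-yl entered, so its departure may move the number modestly upward. Compound 1 carries dimethylamino too, and with compound 1 at 9.7 mg/kg a large rise seems unlikely, although its chain differs. With so few compounds this reading stays tentative.

The expected change is a 1.8-fold higher number from compound 3 to compound 4 (0.24 log units; within the scatter) and so a small upward step that need not clear the scatter. Compound 4 is estimated at 14 mg/kg with an expected range from 6 mg/kg to 32 mg/kg.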

Compound 4, dose for half-maximal effect: 17.3 mg/kg
The estimate for compound 4 lay 1.2-fold (0.09 log units) below the measured number; low and high end bracket the measured number.
By their numbers in this assay, from the lowest: compounds 3, 1, 4 and 2 (each within the scatter of the next, the first and the last beyond it).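

In this assay this place on a saturated chain carbon bound to a triple-bonded carbon now reads from both sides: dimethylamino in place of 1H-imidazol-1-yl gives a 2.2-fold higher number from compound 3 to compound 4 (0.33 log units; beyond the scatter) and dimethylamino in place of pyrrolidin-1-yl gives a 1.2-fold lower number from compound 2 to compound 4 (0.08 log units; within the scatter) so that, of the three groups shown on this chain, 1H-imidazol-1-yl alone sets its compound apart. The added methyl on the chain carbon bound to an amide-type nitrogen and a triple-bonded carbon can now be read alone, and a 1.8-fold higher number from compound 1 to compound 4 (0.25 log units; within the scatter) shows that methyl in place of hydrogen does not move the number beyond the scatter. Nothing measured here accounts for these differences.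

As far as these compounds go, whether a piperidine ring or a primary amine at this place would stand with dimethylamino and pyrrolidin-1-yl or with 1H-imidazol-1-yl remains open. So does whether the step seen with 1H-imidazol-1-yl carries over to the chain with hydrogen in place of methyl.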